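The source may hold more compounds than are shown below. What is called first, only, known or untested is meant among the compounds shown, and "the series" means these compounds.

Compound 1 `COc1ccc(/C=C(/Sc2ccc(C)cc2)C(=O)c2ccc(Cl)cc2)cc1O` stands at the low end of the numbers in hand: in a functional assay on DU-145 cells (Homo sapiens) for inhibition, read by trypan blue exclusion, with a stated time of 96 h (on this read-out higher numbers stand for weaker inhibition of growth and lower numbers for stronger inhibition of growth), compound 1 gives 1000 nM. Compound 3 `Cc1ccc(S(=O)(=O)/C(=C/c2ccc(C)s2)C(=O)c2ccc(Cl)cc2)cc1` gives 50000 nM in this assay, a far higher number than compound 1, and that gap lies beyond the scatter. Compound 2 `CN(C)c1ccc(/C=C(\C(=O)c2ccc(C(=O)O)cc2)S(=O)(=O)Cc2ccc(Cl)cc2)cc1` reaches only a limit in this assay (the limit of > 100000 nM in this assay, at which 1 of the 3 values shown sits), giving > 100000 nM. Compound 4 `Cc1ccc(S/C(=C/c2c[nH]c3ccccc23)C(=O)c2ccc(Cl)cc2)cc1` differs from compound 1 in one place: 1H-indol-3-yl in place of 3-hydroxy-4-methoxyphenyl on a double-bonded chain carbon bound to a double-bonded chain carbon. For the measured compounds named here, no step between measured compounds matches this change, so the direction is uncertain; a moderate rise in the number, close to the edge of the scatter, seems the likeliest outcome, and the step of a 3.0-fold higher number from compound 1 to compound 4 (0.48 log units; beyond the scatter) is the expected one. Compound 4 is therefore estimated at 3000 nM, with a range from 500 nM to 30000 nM.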

Compound 4, concentration for 50% growth inhibition: 10000 nM
Estimate against measurement, compound 4: 3.3-fold (0.52 log units) below, and the stated range covers the measured number.
By their numbers in this assay, from the lowest: compound 1; then compound 4; then compound 3. At a limit, above all of these: compound 2.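

With the rest of compound 1 held fixed, placing 1H-indol-3-yl on the double-bonded chain carbon gives, in this assay, a 10-fold higher number from compound 1 to compound 4 (1.00 log units; beyond the scatter), so growth inhibition at this position depends on which group sits there. The two groups match in heavy atoms and hydrogen-bond donors but differ in hydrogen-bond acceptors and rings. Nothing measured here gives a reason for the rise.

The compounds shown leave open which part of 3-hydroxy-4-methoxyphenyl matters. A plain phenyl, or a phenyl carrying only the hydroxy or only the methoxy, would separate those parts.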